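From 1-benzofuran-2-yl to ethynyl on the shared core

This account rests on a few compounds, and the source may have more. Where it says the series, first, only, none or still open, it means among the compounds named here.

Compound 1 `Cc1nc(N)c2c(-c3ccco3)cn([C@@H]3O[C@H](CO)[C@@H](O)[C@H]3O)c2n1` gives > 100000 nM in an ADME assay on BJ cells (Homo sapiens), read by MTT assay, with a stated time of 72 h (a higher number here means a weaker inhibitor, a lower number a stronger inhibitor), as a limit of the assay. In this assay compound 2 `Cc1nc(N)c2c(-c3cccs3)cn([C@@H]3O[C@H](CO)[C@@H](O)[C@H]3O)c2n1` gives > 100000 nM as a limit too. Compound 3 `Cc1nc(N)c2c(-c3cc4ccccc4o3)cn([C@@H]3O[C@H](CO)[C@@H](O)[C@H]3O)c2n1` stands at > 100000 nM as a limit as well. All three share that one limit (the limit of > 100000 nM in this assay, at which 3 of the 3 values shown sit). Compound 4 `C#Cc1cn([C@@H]2O[C@H](CO)[C@@H](O)[C@H]2O)c2nc(C)nc(N)c12` carries ethynyl in place of 1-benzofuran-2-yl on an aromatic carbon. Among the compounds with values here, the steps that bear on this are a step that the two limits leave unreadable from compound 1 to compound 2 and a step that the two limits leave unreadable from compound 1 to compound 3 and also a step that the two limits leave unreadable from compound 2 to compound 3 so none offers a size to carry over. The expected change is an at least 2.0-fold lower number from compound 3 to compound 4 (0.30 log units; that floor lies within the scatter) toward stronger inhibition, if any, and is only loosely estimated. For compound 4 the estimated value is 50000 nM within an expected range of 5000 nM to 100000 nM and another limit reading remains likely.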

Compound 4, half-maximal inhibitory concentration: > 100000 nM
Compound 4 ended at the assay's limit; the forecaster's own chance of this, stated with the estimate: 55%; at least 2.0-fold (0.30 log units) between middle value and limit.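

In this assay, within the data shown here, compound 4 gives > 100000 nM, a limit of the assay, so no step between it and compound 1, compound 2 or compound 3 can be read. The compounds shown leave open how these four groups on the shared core differ, as all sit at one limit: the limit of > 100000 nM in this assay, at which 4 of the 4 values shown sit.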